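Extending an Alkyl Chain on a Shared Core

The compounds below may be only part of what the source reports. "The series", "measured", "known", "first", "only" and "open" are said of these compounds alone.

Of the compounds shown here, three built on one common core have been measured in a functional assay on a cell-free system (plasma) for inhibition of platelet-activating factor acetylhydrolase (Homo sapiens), tested at 100 nM; on this read-out lower numbers stand for less inhibition and higher numbers for more inhibition at the one concentration tested (going by the name of the read-out). Compound 1 `CCCCCCCCN(C)C(=O)Cn1cc(Cc2cnc(OCC)nc2)c(=O)nc1SCc1ccc(F)cc1` gives 23%. Compound 2 `CCCCCCCCN(C)C(=O)Cn1cc(Cc2cnc(O)nc2)c(=O)nc1SCc1ccc(F)cc1` gives 66%, and compound 3 `CCCCCCCCN(C)C(=O)Cn1cc(Cc2cnc(=O)n(C)c2)c(=O)nc1SCc1ccc(F)cc1` gives 55%. Compound 3 therefore stands second highest of the three numbers: its nearest neighbour is reached through a number 11 percentage points lower from compound 2 to compound 3 (beyond the scatter), and its furthest through a number 32 percentage points higher from compound 1 to compound 3 (beyond the scatter).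

Compound 4 `CCCCCCCCN(C)C(=O)Cn1cc(Cc2cnc(=O)n(CC)c2)c(=O)nc1SCc1ccc(F)cc1` differs from compound 3 by methyl in place of hydrogen on a saturated chain carbon bound to an aromatic nitrogen. For the measured compounds named here, two measured steps bear on this change. The first, a number 43 percentage points higher from compound 1 to compound 2 (beyond the scatter), shows that removing an ethyl from an oxygen on the aromatic ring raised inhibition strongly. The second, a number 11 percentage points lower from compound 2 to compound 3 (beyond the scatter), shows that adding a methyl on the ring nitrogen lowered it by a modest amount. Both point the same way: more carbon at this end of the core goes with less inhibition, although the two steps differ considerably in size. Growing methyl into ethyl is consequently expected to reduce inhibition modestly, beyond the scatter but well short of the first step. Compound 4 is thus expected to give 42%, within a range from 25% to 58%. That estimate corresponds to an expected step of a number 13 percentage points lower from compound 3 to compound 4 (beyond the scatter).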

Compound 4, a percentage reported as inhibition, at one concentration (the size of the read-out at that concentration, not a potency): 48%
Estimate against measurement, compound 4: 6 percentage points below; the range from low to high includes it.
By their numbers in this assay, from the lowest: compound 1; then compounds 4 and 3 (each within the scatter of the next); then compound 2.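

In this assay, for the compounds shown here, methyl in place of hydrogen on a saturated chain carbon bound to an aromatic nitrogen gives a number 7 percentage points lower from compound 3 to compound 4 (within the scatter) and so does not separate ethyl from methyl at this place, a comparison the earlier compounds could not offer, as only compound 3 carried a chain on that nitrogen. The ethyl compound still differs from the compound without a chain there, with a number 18 percentage points lower from compound 2 to compound 4 (beyond the scatter) in this read-out, while the comparison with the isomeric compound shows a number 25 percentage points higher from compound 1 to compound 4 (beyond the scatter) when the same ethyl sits on the ring nitrogen rather than on an oxygen on the aromatic ring, so the place of attachment matters more here than the step from methyl to ethyl. Nothing available explains why these groups differ in this way, and the account therefore stays with the numbers alone.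

The compounds shown leave open whether a longer chain, such as propyl or butyl, on the ring nitrogen would stay level with methyl and ethyl or fall away from them. They also leave open what an amine or a carboxylic acid at the end of such a chain would do to inhibition at this concentration.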